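Losing the Chloro Group in a Weakly Cytotoxic Series

This account rests on a few compounds, and the source may have more. Where it says the series, first, only, none or still open, it means among the compounds named here.

Compounds built on a shared core have been tested in a functional assay on SW480 cells (Homo sapiens) for cytotoxicity, read by MTT assay, with a stated time of 48 h; a lower number here means a stronger inhibitor, a higher number a weaker inhibitor. Compound 3 `COc1cc([C@H]2C[C@]2(CO)C(=O)Nc2ccccc2Cl)cc(OC)c1OC` gives 40200 nM. Compound 1 `CCOC(=O)[C@]1(C(=O)Nc2ccccc2)C[C@@H]1c1cc(OC)c(OC)c(OC)c1` gives 31700 nM, and these two numbers lie within the scatter of each other, so neither can be ranked over the other.

Compound 4 `COc1cc([C@H]2C[C@]2(CO)C(=O)Nc2ccccc2)cc(OC)c1OC` has not yet been measured. It differs from compound 3 in one place, with hydrogen in place of chloro on an aromatic carbon, ortho to a large group (hydrogen in place of chloro on an aromatic carbon). Cut one bond further out, the same difference reads 2-chlorophenyl to phenyl. Within the data shown here, no measured pair shows this change on its own, so there is no direct guide to its size.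

The nearest hint is indirect. Compound 2 `COc1cc([C@H]2C[C@@]2(CO)C(=O)Nc2ccccc2)cc(OC)c1OC`, which also bears a phenyl, gives > 100000 nM, a limit of the assay and not a number. That limit suggests a shift towards weaker inhibition rather than stronger. The expected change in this assay is therefore a small weakening, estimated as a 1.5-fold higher number from compound 3 to compound 4 (0.17 log units; within the scatter), and it may not clear the scatter. Compound 4 is expected at 60000 nM, with an estimated range of 25000 nM to 100000 nM.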

Compound 4, half-maximal inhibitory concentration: > 100000 nM
Compound 4 gave a limit, no number; the forecaster's own chance of this, stated with the estimate: 30%; at least 1.6-fold (0.22 log units) between middle value and limit.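

In this assay compound 4 gives > 100000 nM as a limit of the assay and not a number. Hydrogen in place of chloro on an aromatic carbon, ortho to a large group, now has a step of its own (an at least 2.4-fold higher number from compound 3 to compound 4 (0.39 log units; beyond the scatter)), so with this core and this configuration the 2-chlorophenyl compound reads as a number while the phenyl compound does not, although compound 1 shows that a phenyl compound can still give a number when it carries ethoxycarbonyl; hydroxymethyl in place of ethoxycarbonyl on a saturated ring carbon also has a step (an at least 3.1-fold higher number from compound 1 to compound 4 (0.49 log units; beyond the scatter)), and this one is likewise beyond the scatter. No step can be read from compound 2 to compound 4, because both stand at the same limit: the limit of > 100000 nM in this assay, at which 2 of the 4 values shown sit.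

The compounds shown leave open how far past the limit compound 4 lies, and whether the drawn configuration matters at all for this phenyl pair. They also leave open whether bromo or methoxy on this aromatic carbon would act as chloro does, and whether an amine or a carboxylic acid in place of the hydroxymethyl would change the reading.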